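The source may report more compounds than this note shows. Statements on the series, on what has been measured and on what is new or still open speak of the compounds shown alone.

Measured so far in a functional assay on the whole organism (strain Wistar Albino) for inhibition, with Rattus norvegicus as the target, read by paw edema, with a stated time of 4 h, at a dose of 20 mg/kg; a lower number here means less inhibition, a higher number more inhibition at the dose given (going by the name of the read-out):
compound 1, `COc1ccc(Cl)c(-c2nnc3sc(-c4ccnc(Cl)c4)nn23)c1`, gives 27.2%
compound 2, `COc1ccc(Cl)c(-c2nnc3sc(-c4ccnc(F)c4)nn23)c1`, gives 28.1%
compound 3, `COc1ccc(Cl)c(-c2nnc3sc(Cc4c[nH]c5ccc(OC)cc45)nn23)c1`, gives 33.9%

Compound 3 stands at the highest of the three numbers, but its gaps to compound 2 and to compound 1 are both within the scatter, so no order among the three is established. Among the measured compounds shown here, the only measured step, a number 0.9 percentage points higher from compound 1 to compound 2 (within the scatter), is likewise within the scatter and concerns a halogen exchange on a different part of the shared core.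

Compound 4, `COc1ccc2[nH]cc(Cc3nn4c(-c5ccoc5C)nnc4s3)c2c1`, differs from compound 3 by 2-methylfuran-3-yl in place of 2-chloro-5-methoxyphenyl on an aromatic carbon. For the measured compounds named here, no measured step bears on this position or on this kind of exchange, and the series so far shows no change beyond the scatter at all. The expectation for compound 4 therefore rests on compound 3 alone, with a wide range to allow for an untested replacement. The expected step is a number 2.9 percentage points lower from compound 3 to compound 4 (within the scatter), with no direction claimed beyond the scatter. Compound 4 is estimated at 31%, expected to fall between 19% and 43%.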

Compound 4, a percentage reported as inhibition, in the whole organism at one dose (the size of the read-out at that dose, not a potency): 30.8%
Estimate against measurement, compound 4: 0.2 percentage points above, and the stated range covers the measured number.
By their numbers in this assay, from the lowest: compounds 1, 2, 4 and 3 (each within the scatter of the next).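

This position now has a measured step. In this assay, 2-methylfuran-3-yl in place of 2-chloro-5-methoxyphenyl, on the aromatic carbon between two ring nitrogen atoms, gives a number 3.1 percentage points lower from compound 3 to compound 4 (within the scatter), so exchanging a six-membered aromatic ring of carbon only, with its chlorine, for a five-membered aromatic ring with 1 hetero atom and fewer heavy atoms produces no difference beyond the scatter. No supporting data bear on why this exchange leaves the read-out within the scatter.

Whether any group on this carbon can move the number beyond the scatter remains open, as the two groups shown cannot separate the ring size, the chlorine and the methyl. A primary amine or a carboxylic acid here would test a far more distant kind of replacement.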